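Chloro to acetamido on the aryl group

This account rests on a few compounds, and the source may have more. Where it says the series, first, only, none or still open, it means among the compounds named here.

Measured in a functional assay on SMMC-7721 cells (Homo sapiens) for cytotoxicity, read by MTT assay, with a stated time of 24 h; on this read-out higher numbers stand for weaker inhibition and lower numbers for stronger inhibition:
- compound 1 `Cc1ccc(S(=O)(=O)N2C/C(=C\c3ccncc3)C(=O)/C(=C/c3ccccc3F)C2)cc1`: 13200 nM
- compound 2 `O=C1/C(=C/c2ccncc2)CN(S(=O)(=O)c2ccc(C(F)(F)F)cc2)C/C1=C\c1ccccc1F`: 11100 nM
- compound 3 `O=C1/C(=C/c2ccncc2)CN(S(=O)(=O)c2ccc(Cl)cc2)C/C1=C\c1ccccc1F`: 9600 nM

In this assay compound 3 gives 9600 nM, a value that cannot be separated from the other two. The steps that reach it are a 1.2-fold lower number from compound 2 to compound 3 (0.06 log units; within the scatter) and a 1.4-fold lower number from compound 1 to compound 3 (0.14 log units; within the scatter). The third measured step is a 1.2-fold lower number from compound 1 to compound 2 (0.08 log units; within the scatter).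

The next change leads to compound 4 `CC(=O)Nc1ccc(S(=O)(=O)N2C/C(=C\c3ccncc3)C(=O)/C(=C/c3ccccc3F)C2)cc1`. Here acetamido stands in place of chloro on an aromatic carbon, para to a large group, so that 4-chlorophenyl becomes 4-acetamidophenyl: acetamido in place of chloro on an aromatic carbon.

All three measured steps exchange the group at this same place, and none left the scatter. Within the data shown here, they are the only guide, yet no measured compound carries acetamido, so the series offers no direct step for this group. The expectation therefore rests on the flat set of values around compound 3 at 9600 nM, and no step beyond the scatter is expected, with no firm direction. The expected step is a 1.1-fold higher number from compound 3 to compound 4 (0.06 log units; within the scatter). For compound 4 the estimated value is 11000 nM, with an expected range of 5500 nM to 22000 nM.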

Compound 4, half-maximal inhibitory concentration: 13400 nM
Compound 4: the middle estimate sits 1.2-fold (0.09 log units) below what was measured, within the range that was stated.
By their numbers in this assay, from the lowest: compounds 3, 2, 1 and 4 (each within the scatter of the next).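

Acetamido brings 4 heavy atoms, a hydrogen-bond donor and a hydrogen-bond acceptor to this place on the aromatic ring, where chloro has 1 heavy atom and neither donor nor acceptor, yet in this assay the change stays within the scatter (a 1.4-fold higher number from compound 3 to compound 4 (0.14 log units; within the scatter)). The comparisons with the other two groups at this place also stay within the scatter (a 1.2-fold higher number from compound 2 to compound 4 (0.08 log units; within the scatter); a 1.0-fold higher number from compound 1 to compound 4 (0.01 log units; within the scatter)), so the flat set now spans four groups, including the first one here with a hydrogen-bond donor and acceptor, and none of the four can be separated from the others in this read-out. Nothing available accounts for this flatness.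

From the compounds shown here alone, whether a free amine, a carboxylic acid or a longer chain at this place on the aromatic ring would move the value beyond the scatter remains open. The compounds shown also change only this one place, so they leave open whether the same flatness would hold with a different group elsewhere on the shared core.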